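The source may report more compounds than this note shows. Statements on the series, on what has been measured and on what is new or still open speak of the compounds shown alone.

In a functional assay on C6 cells (Rattus norvegicus) for cytotoxicity, read by MTT assay, with a stated time of 24 h, tested at 100 ug/mL (on this read-out higher numbers stand for a weaker effect at the one concentration tested and lower numbers for a stronger effect), the measured compounds gave:
Compound 1 `Cc1nnc(SCC(=O)N/N=c2/scc(-c3ccccc3)n2-c2ccccc2)s1`: 61.8%
Compound 2 `O=C(CSc1ncccn1)N/N=c1/scc(-c2ccc(Br)cc2)n1-c1ccccc1`: 67.6%
Compound 3 `Cn1cnnc1SCC(=O)N/N=c1/scc(-c2ccccc2)n1-c1ccccc1`: 38.6%

Compound 1 stands second highest of these three numbers. Compound 2 lies within the usual scatter of it, so the two cannot be told apart, while the step of a number 23.2 percentage points lower from compound 1 to compound 3 (beyond the scatter) is beyond the scatter and comes from exchanging the ring attached to the sulfur. Compound 4 `Cc1ccc(-c2cs/c(=N/NC(=O)CSc3nnc(C)s3)n2-c2ccccc2)cc1` differs from compound 1 by methyl in place of hydrogen on an aromatic carbon. Going by the values given here, no measured step touches this ring; the only step beyond the scatter sits elsewhere, and compound 2, which carries a different group on this same ring, gives a value indistinguishable from compound 1. A step of a number 0.2 percentage points higher from compound 1 to compound 4 (within the scatter) is therefore expected, nothing beyond the scatter. Compound 4 is estimated at 62%, between 45% and 80%.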

Compound 4, a percentage reported as activity, at one concentration (the size of the read-out at that concentration, not a potency): 31.5%
Compound 4: the middle estimate sits 30.5 percentage points above what was measured; measured number outside the range, below it.
By their numbers in this assay, from the lowest: compounds 4 and 3 (each within the scatter of the next); then compounds 1 and 2 (each within the scatter of the next).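

In this assay, going from phenyl to 4-methylphenyl gives a number 30.3 percentage points lower from compound 1 to compound 4 (beyond the scatter), and a lower number stands for a stronger effect. So this place, on an aromatic carbon para to a large group, responds strongly to a single added carbon. Nothing available explains why the methyl does this. Still open, going by these compounds, is whether a methoxy group or an amine at this place would give a similar number. Also open, on these data alone, is whether methyl would do the same with a different ring on the sulfur.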